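A few compounds are considered here, and "the series" means these few. Any claim that something is new, unique, unknown or untested is made for them only; others in the source may bear on it.

Measured compounds in a functional assay on A549 cells (Homo sapiens) for cytotoxicity, with a stated time of 48 h; a higher number here means a weaker inhibitor, a lower number a stronger inhibitor:
- compound 1 `CCCCCOc1ccc2oc(/C=C/[S+](C)[O-])cc(=O)c2c1`: compound 1 gives 1600 nM
- compound 2 `C[S+]([O-])/C=C/c1cc(=O)c2ccccc2o1`: compound 2 gives 1900 nM
- compound 3 `Cc1ccc2oc(/C=C/[S+](C)[O-])cc(=O)c2c1`: compound 3 gives 1700 nM

Compound 3 has the second highest of the three numbers, but all three lie within the scatter of one another, so no ordering among them can be claimed. Compound 4 `C[S+]([O-])/C=C/c1cc(=O)c2cc(O)ccc2o1` has not yet been measured. Its change from compound 3: hydroxy in place of methyl on an aromatic carbon. Among the measured compounds shown here, the steps that bear on it are the earlier exchanges at this same aromatic carbon, a 1.1-fold higher number from compound 1 to compound 3 (0.03 log units; within the scatter) and a 1.1-fold lower number from compound 2 to compound 3 (0.05 log units; within the scatter), where pentyloxy, hydrogen and methyl all gave numbers within the scatter. A hydroxy at this carbon is not covered by any measured pair, yet nothing seen so far gives grounds to expect a step beyond the scatter. The step expected for compound 4 is no change at the digits printed from compound 3 to compound 4 (within the scatter). Compound 4 is expected near 1700 nM, with a range of 800 nM to 3600 nM.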

Compound 4, half-maximal inhibitory concentration: 10500 nM
Beside the measured number, compound 4's estimate is 6.2-fold (0.79 log units) below it, outside the stated range (above it).
By their numbers in this assay, from the lowest: compounds 1, 3 and 2 (each within the scatter of the next); then compound 4.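

In this assay this aromatic carbon proves sensitive to its group: hydroxy in place of methyl gives a 6.2-fold higher number from compound 3 to compound 4 (0.79 log units; beyond the scatter), hydroxy in place of hydrogen gives a 5.5-fold higher number from compound 2 to compound 4 (0.74 log units; beyond the scatter), and hydrogen in place of pentyl on the oxygen gives a 6.6-fold higher number from compound 1 to compound 4 (0.82 log units; beyond the scatter). Pentyloxy, hydrogen and methyl stayed within the scatter of one another, so only hydroxy separates here, and an oxygen at this carbon is not enough, since compound 1 also carries one. No measurement at hand explains this step. Open, on these data alone, is whether methoxy, an amine or a carboxylic acid at this carbon would follow compound 4 or the other three.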